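From diethylamino to methylamino on the propyl chain

A few compounds are considered here, and "the series" means these few. Any claim that something is new, unique, unknown or untested is made for them only; others in the source may bear on it.

Measured in an ADME assay on Vero cells (Chlorocebus sabaeus) for cytotoxicity, read by neutral red uptake, with a stated time of 3 days; a higher number here means that more compound is tolerated, a lower number that less compound is tolerated:

Compound 1 `CC(CN(C)C)NC(=O)c1cc(C2CC2)nc2c1cnn2C(C)C`: > 300000 nM, which is a limit of the assay
Compound 2 `CC(CN)NC(=O)c1cc(C2CC2)nc2c1cnn2C(C)C`: 164000 nM
Compound 3 `CCN(CC)CCCNC(=O)c1cc(C2CC2)nc2c1cnn2C(C)C`: 130000 nM

Compound 3 gives 130000 nM, and the nearest number is that of compound 2, with a 1.3-fold lower number from compound 2 to compound 3 (0.10 log units; within the scatter). Against the limit of compound 1, the data show an at least 2.3-fold lower number from compound 1 to compound 3 (0.36 log units; beyond the scatter).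

Compound 4 `CNCCCNC(=O)c1cc(C2CC2)nc2c1cnn2C(C)C` keeps the shared core and differs at one place: methylamino in place of diethylamino on a saturated chain carbon, three bonds along the chain from an amide-type nitrogen. Here methylamino stands in place of diethylamino, three bonds along the chain from an amide-type nitrogen.

Among the compounds with values here, no measured step makes this exact change. The closest is an at least 1.8-fold lower number from compound 1 to compound 2 (0.26 log units; that floor lies within the scatter), where amino replaces dimethylamino on a different chain. The measured step of a 1.3-fold lower number from compound 2 to compound 3 (0.10 log units; within the scatter) shows two different amine chains giving numbers within the scatter. A change beyond the scatter in this assay is therefore not expected. The expected step is a 1.2-fold higher number from compound 3 to compound 4 (0.06 log units; within the scatter). Compound 4 is expected at 150000 nM, with an estimated range of 80000 nM to 280000 nM.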

Compound 4, half-maximal cytotoxic concentration: 281000 nM
For compound 4 the middle estimate is 1.9-fold (0.27 log units) below the measured one; measured number outside the range, above it.
By their numbers in this assay, from the lowest: compounds 3, 2 and 4 (each within the scatter of the next, the first and the last beyond it). At a limit, above all of these: compound 1.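

Within the propyl chain, methylamino in place of diethylamino gives a modest change in this assay (a 2.2-fold higher number from compound 3 to compound 4 (0.33 log units; beyond the scatter)), the first step at this place with a measured number on both sides that is read as beyond the scatter. The data show a 1.7-fold higher number from compound 2 to compound 4 (0.23 log units; within the scatter) and a 1.3-fold lower number from compound 2 to compound 3 (0.10 log units; within the scatter), so the amine on the propyl chain separates compound 3 from compound 4, while compound 2 cannot be told from either. Compound 1 gives > 300000 nM, which is a limit: the limit of > 300000 nM in this assay, at which 1 of the 4 values shown sits. Against this limit the data show only an at least 1.0-fold lower number from compound 1 to compound 4 (0.02 log units; that floor lies within the scatter), so the true size of this step cannot be read.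

The compounds shown leave open where dimethylamino or a plain amino group on the propyl chain would fall relative to methylamino and diethylamino. They also leave open whether a longer chain carrying methylamino would keep the number of compound 4.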